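The source may report more compounds than this note shows. Statements on the series, on what has been measured and on what is new or still open speak of the compounds shown alone.

Measured compounds:
compound 1 `CC(=O)N1CCc2oc(=O)n(C(=O)NCCCCc3ccccc3)c2C1`: 293 nM
compound 2 `O=C(NCCCCc1ccccc1)n1c2c(oc1=O)CCN(Cc1ccccc1)C2`: 436 nM
compound 3 `O=C(NCCCCc1ccccc1)n1c(=O)oc2ccncc21`: 6 nM

In an assay on HEK293 cells for inhibition of acid ceramidase (Homo sapiens), read by fluorescence, with stated times of 10 min and 3 h (on this read-out lower numbers stand for stronger inhibition and higher numbers for weaker inhibition), compound 2 gives 436 nM, the weakest-looking number of the three, though the gap to compound 1, a 1.5-fold higher number from compound 1 to compound 2 (0.17 log units; within the scatter), lies within the scatter; compound 3, at 6 nM, is far stronger. Compound 4 `CN1CCc2oc(=O)n(C(=O)NCCCCc3ccccc3)c2C1` differs from compound 2 by hydrogen in place of phenyl on a saturated chain carbon bound to an amine nitrogen in a ring, that is, benzyl to methyl. Among the measured compounds shown here, the only measured step at this position is the swap from acetyl to benzyl, a 1.5-fold higher number from compound 1 to compound 2 (0.17 log units; within the scatter), which changed nothing beyond the scatter. Taking the benzyl off to leave methyl is therefore expected to move this assay little, with no step beyond the scatter in either direction: compound 4 is estimated at 350 nM, range 150 nM to 900 nM, a step of a 1.2-fold lower number from compound 2 to compound 4 (0.10 log units; within the scatter).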

Compound 4, half-maximal inhibitory concentration: 516 nM
For compound 4 the middle estimate is 1.5-fold (0.17 log units) below the measured one; low and high end bracket the measured number.
By their numbers in this assay, from the lowest: compound 3; then compounds 1, 2 and 4 (each within the scatter of the next).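

In this assay, hydrogen in place of phenyl gives a 1.2-fold higher number from compound 2 to compound 4 (0.07 log units; within the scatter) and methyl in place of acetyl gives a 1.8-fold higher number from compound 1 to compound 4 (0.25 log units; within the scatter). Both steps lie within the scatter, so acetyl, benzyl and methyl on this amine nitrogen in a ring cannot be told apart, and the phenyl of the benzyl adds no measurable strength. No supporting data bear on why these groups read alike. Still open, from the compounds shown here alone, is whether an amine with hydrogen on this nitrogen, or a longer chain ending in a carboxylic acid, would move the number beyond the scatter.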